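From azetidin-1-yl to benzylamino on a shared core

A few compounds are considered here, and "the series" means these few. Any claim that something is new, unique, unknown or untested is made for them only; others in the source may bear on it.

In a functional assay on MGC-803 cells (Homo sapiens) for inhibition, read by sulforhodamine B assay (on this read-out lower numbers stand for stronger inhibition and higher numbers for weaker inhibition), compound 1 `O=C1C(Nc2ccccc2)=CC(=O)c2c1nc1n2[C@H]2OC[C@@H](O)[C@H]2OC1`, which carries anilino on the shared core, gives 1830 nM. Compound 2 `O=C1C(N2CCC2)=CC(=O)c2c1nc1n2[C@H]2OC[C@@H](O)[C@H]2OC1`, with azetidin-1-yl in its place, gives > 16000 nM, and this is a limit of the assay, not a number. Compound 2 therefore offers no exact starting value. Compound 3 `O=C1C(NCc2ccccc2)=CC(=O)c2c1nc1n2[C@H]2OC[C@@H](O)[C@H]2OC1` has benzylamino in place of azetidin-1-yl on a double-bonded ring carbon. Among the compounds with values here, one measured step bears on this change, and it is an at least 8.7-fold higher number from compound 1 to compound 2 (0.94 log units; beyond the scatter), which came with the same azetidin-1-yl group. Benzylamino, like the anilino of compound 1 at 1830 nM, brings an aromatic ring, so much of that step is expected to be undone in this assay, towards a lower number. A single step is thin support, and benzylamino is not the same group as anilino, so the range stays wide. The expected change is an at least 4.5-fold lower number from compound 2 to compound 3 (0.66 log units; beyond the scatter). Compound 3 is estimated at 3500 nM, with an expected range from 1200 nM to 12000 nM.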

Compound 3, half-maximal inhibitory concentration: 3490 nM
Compound 3: the middle estimate sits 1.0-fold (0.00 log units) above what was measured; measured number inside the range.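

Benzylamino in place of azetidin-1-yl gives an at least 4.5-fold lower number from compound 2 to compound 3 (0.66 log units; beyond the scatter) in this assay, so the weak result for compound 2 does not mean that only anilino gives a measurable value at this double-bonded ring carbon. Benzyl in place of phenyl on the amine nitrogen gives a 1.9-fold higher number from compound 1 to compound 3 (0.28 log units; within the scatter), so the assay cannot tell these two groups apart. Compound 2 stands at a limit of the assay and not at a number, so the step from it gives only a minimum size: the limit of > 16000 nM in this assay, at which 1 of the 3 values shown sits.

Benzylamino differs from azetidin-1-yl in both its six-membered aromatic ring and its hydrogen-bond donor, and the compounds shown cannot separate these two differences; cyclohexylamino, which keeps the amine hydrogen without an aromatic ring, and N-methylanilino, which keeps the aromatic ring without that hydrogen, would pull them apart. From the compounds shown here alone, it also remains open whether a chlorine or a methoxy group on the aromatic ring of benzylamino would shift the value, or whether a longer chain, such as 2-phenylethylamino, would keep it within the scatter.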